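A few compounds are considered here, and "the series" means these few. Any claim that something is new, unique, unknown or untested is made for them only; others in the source may bear on it.

Values in a functional assay on SW-620 cells (Homo sapiens) for cytotoxicity; on this read-out lower numbers stand for stronger inhibition of growth and higher numbers for weaker inhibition of growth:
- Compound 1 `COc1ccc(C2=C(c3ccc(SC)cc3)CC3CCCN3C2=O)cc1O`: 20000 nM
- Compound 2 `COc1ccc(C2=C(c3ccc(SC)cc3)CC3CCCN3C2=O)cc1C`: 500 nM
- Compound 3 `CSc1ccc(C2=C(c3ccc(O)c(O)c3)C(=O)N3CCCC3C2)cc1`: 50000 nM

Of the three, compound 3 has the highest number in this assay, at 50000 nM. Compound 4 `CSc1ccc(C2=C(c3ccc(F)cc3)C(=O)N3CCCC3C2)cc1` differs from it in one place: 4-fluorophenyl in place of 3,4-dihydroxyphenyl on a double-bonded ring carbon. Among the measured compounds shown here, three measured steps bear on this. Replacing a hydroxy group with methyl gave a large drop, a 40-fold lower number from compound 1 to compound 2 (1.60 log units; beyond the scatter). Introducing 3,4-dihydroxyphenyl gave a large rise, a 100-fold higher number from compound 2 to compound 3 (2.00 log units; beyond the scatter), and a modest one, a 2.5-fold higher number from compound 1 to compound 3 (0.40 log units; beyond the scatter). None of these steps tests 4-fluorophenyl, so a clear but smaller fall in the number is expected, not the full size of the largest step. The expected change is a 10-fold lower number from compound 3 to compound 4 (1.00 log units; beyond the scatter). For compound 4 the estimated value is 5000 nM, with an expected range of 1000 nM to 25000 nM.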

Compound 4, concentration for 50% growth inhibition: 500 nM
The estimate for compound 4 lay 10-fold (1.00 log units) above the measured number; measured number outside the range, below it.
By their numbers in this assay, from the lowest: compounds 2 and 4 (each within the scatter of the next); then compound 1; then compound 3.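

In this assay, 4-fluorophenyl on this double-bonded ring carbon gave a 100-fold lower number from compound 3 to compound 4 (2.00 log units; beyond the scatter) and a 40-fold lower number from compound 1 to compound 4 (1.60 log units; beyond the scatter), showing that this position tolerates a ring without hydroxy groups and a much simpler substituent than those tested earlier. The change to 4-fluorophenyl also gave no change at the digits printed from compound 2 to compound 4 (within the scatter), so two differently substituted rings without hydroxy groups perform alike here. No supporting evidence accounts for these differences. On these data alone, it remains open whether an unsubstituted phenyl, a 4-aminophenyl or a 4-carboxyphenyl group at this carbon would give a similar number.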